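The source may report more compounds than this note shows. Statements on the series, on what has been measured and on what is new or still open speak of the compounds shown alone.

Measured so far in an assay on HEK293 cells for agonist activity at transient receptor potential cation channel subfamily M member 8 (Homo sapiens), read by fluorescence and calcium flux, with a stated time of 15 min; on this read-out higher numbers stand for an effect only at larger amounts of compound and lower numbers for an effect already at smaller amounts:
- compound 1 `Cc1ccc(OCC(=O)N(Cc2cccs2)c2c[nH]nc2C)cc1`: 0.4 nM
- compound 2 `Cc1ccc(OCC(=O)N(CCO)Cc2cccs2)cc1`: 900 nM
- compound 3 `Cc1ccc(OCC(=O)N(C)Cc2cccs2)cc1`: 400 nM

Compound 3 holds the second highest of the three numbers in this assay; its nearest neighbour is compound 2, from which it differs by a 2.3-fold lower number from compound 2 to compound 3 (0.35 log units; beyond the scatter), while compound 1 lies furthest away, with a 1000-fold higher number from compound 1 to compound 3 (3.00 log units; beyond the scatter) separating them. The unmeasured compound 4 `Cc1ccc(OCC(=O)N(Cc2cccs2)c2ccon2)cc1` differs from compound 3 in one place: 1,2-oxazol-3-yl in place of methyl on an amide-type nitrogen.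

For the measured compounds named here, the step that bears most directly on this change is the one between compound 1 and compound 3, where a five-membered aromatic ring on the amide-type nitrogen gave way to methyl and produced a 1000-fold higher number from compound 1 to compound 3 (3.00 log units; beyond the scatter). The ring entering in compound 4 is a different five-membered aromatic ring, with two hetero atoms and no hydrogen-bond donor, so the account expects a large step downward in this assay, though not necessarily one that fully recovers the number of compound 1. Compound 4 is therefore estimated at 10 nM, with a range from 1 nM to 100 nM, which would mean an expected step of a 40-fold lower number from compound 3 to compound 4 (1.60 log units; beyond the scatter).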

Compound 4, half-maximal effective concentration: 2 nM
Compound 4: the middle estimate sits 5.0-fold (0.70 log units) above what was measured, within the range that was stated.
By their numbers in this assay, from the lowest: compound 1; then compound 4; then compound 3; then compound 2.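

In this assay, 1,2-oxazol-3-yl on the amide-type nitrogen gives a 200-fold lower number from compound 3 to compound 4 (2.30 log units; beyond the scatter) and a 450-fold lower number from compound 2 to compound 4 (2.65 log units; beyond the scatter), so the large gain over the small chain groups is not confined to 3-methyl-1H-pyrazol-4-yl and does not require a hydrogen-bond donor in the entering ring. Most of the gain survives the ring exchange, yet a gap remains, with a 5.0-fold higher number from compound 1 to compound 4 (0.70 log units; beyond the scatter); these two rings differ in more than one feature, so the compounds cannot assign that gap to any one of them. No measurement offered here explains why either ring has this effect.

From the compounds shown here alone, what a phenyl or cyclopentyl ring would give on this nitrogen remains open, and with it whether the ring must be aromatic or five-membered. Also open, going by these compounds, is whether a methyl group on the 1,2-oxazol-3-yl ring would close the remaining gap.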